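Notes on compound 4: 1-hydroxyethyl at the chain carbon

A few compounds are considered here, and "the series" means these few. Any claim that something is new, unique, unknown or untested is made for them only; others in the source may bear on it.

In a functional assay on the whole organism (Tail, strain ICR) with Mus musculus as the target, in the tail flick test, with a stated time of 30 min, at a dose of 25 umol/kg by the oral route (a higher number here means a stronger effect of the compound at the dose given, a lower number a weaker effect), compound 3 `O=C(O)CNC(=O)CN(c1nc(Cl)nc2[nH]cnc12)C1CC1` gives 32.2%, the second highest of three numbers. Compound 1 `N=C(N)NCCC[C@H](NC(=O)CN(c1nc(Cl)nc2[nH]cnc12)C1CC1)C(=O)O` gives 45.4% and compound 2 `C[C@@H](O)[C@H](NC(=O)CN(c1nc(Cl)nc2[nH]cnc12)C1CC1)C(=O)OCc1ccccc1` gives 21.9%, each separated from compound 3 by more than the scatter. Compound 4 `C[C@@H](O)[C@H](NC(=O)CN(c1nc(Cl)nc2[nH]cnc12)C1CC1)C(=O)O` differs from compound 3 by 1-hydroxyethyl in place of hydrogen on a saturated chain carbon bound to an amide-type nitrogen and a carbonyl carbon. Among the measured compounds shown here, the one measured step at this place is a number 13.2 percentage points lower from compound 1 to compound 3 (beyond the scatter), a modest loss on removing a larger group, so a group entering here may be expected to raise the number. Compound 2 is the nearest measured structure to compound 4, and its value stands lower than that of compound 3. For compound 4 in this assay the expected value is 38%, with a range of 22% to 55%. The expected step is a number 5.8 percentage points higher from compound 3 to compound 4 (within the scatter).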

Compound 4, a percentage reported as activity, at one dose (the size of the read-out at that dose, not a potency): 18.6%
Compound 4: middle estimate off by 19.4 percentage points, on the high side, and the stated range ends above it.
By their numbers in this assay, from the lowest: compounds 4 and 2 (each within the scatter of the next); then compound 3; then compound 1.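

At this chain carbon in this assay, adding a group does not by itself raise the number: 1-hydroxyethyl in place of hydrogen gives a number 13.6 percentage points lower from compound 3 to compound 4 (beyond the scatter), so the direction of the step depends on the group that enters. Against the group of 7 heavy atoms, 1-hydroxyethyl gives a number 26.8 percentage points lower from compound 1 to compound 4 (beyond the scatter), the widest step at this place so far. Hydrogen in place of benzyl on an oxygen next to a carbonyl group gives a number 3.3 percentage points lower from compound 2 to compound 4 (within the scatter), so the benzyl ester and free acid are not separated here.

Open, as far as these compounds go, is whether a methyl or a longer chain ending in an amine at this carbon would stay with 1-hydroxyethyl or approach compound 1. Nothing available accounts for these steps.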